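Replacing a nitrile with a sulfonamide on the amide nitrogen

The source may report more compounds than this note shows. Statements on the series, on what has been measured and on what is new or still open speak of the compounds shown alone.

Three compounds sharing one core were tested in a functional assay on HEK293 cells (Homo sapiens) for cytotoxicity; a higher number here means that more compound is tolerated, a lower number that less compound is tolerated. Compound 1 `COc1ccc([C@H]2CC(=O)N(c3cc(N)cc(N)c3)C2)cc1OC1CCCC1` gives > 10000 nM, a limit of this assay. Compound 3 `COc1ccc([C@H]2CC(=O)N(c3ccc(C)cc3)C2)cc1OC1CCCC1` likewise gives > 10000 nM, again only a limit. Compound 2 `COc1ccc([C@H]2CC(=O)N(c3cccc(C#N)c3)C2)cc1OC1CCCC1` also stands at a limit, > 10000 nM, so every value shown sits at the same boundary the limit of > 10000 nM in this assay, at which 3 of the 3 values shown sit, and the steps a step that the two limits leave unreadable from compound 1 to compound 2, a step that the two limits leave unreadable from compound 1 to compound 3 and a step that the two limits leave unreadable from compound 2 to compound 3 cannot be read in size. Compound 4 `COc1ccc([C@H]2CC(=O)N(c3cccc(NS(=O)(=O)c4ccccc4F)c3)C2)cc1OC1CCCC1` carries ((2-fluorophenyl)sulfonyl)amino in place of cyano on an aromatic carbon. Among the compounds with values here, no measured step bears on this change, since all three values are limits; the only expectation is that compound 4 stays near the same boundary. Compound 4 is therefore expected to give 10000 nM, within a range of 3000 nM to 30000 nM. That estimate corresponds to an expected step of a number no higher from compound 2 to compound 4 (the limit leaves the size open).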

Compound 4, half-maximal cytotoxic concentration: > 10000 nM
Compound 4: only a limit was reported; the forecaster's own chance of this, stated with the estimate: 60%; the middle value lies on the limit itself.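

In this assay, within the data shown here, no step from compound 2 to compound 4 can be read, since both values are only limits: the limit of > 10000 nM in this assay, at which 4 of the 4 values shown sit. The compounds shown leave open at what concentration any of them becomes cytotoxic, and whether ((2-fluorophenyl)sulfonyl)amino in place of cyano changes that.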